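Methyl for methoxy on the aryl of an HDAC6 series

The compounds below may be only part of what the source reports. "The series", "measured", "known", "first", "only" and "open" are said of these compounds alone.

Measured compounds:
compound 1, `Cc1ccccc1-n1nc(-c2ccccc2)nc1CNc1ccc(C(=O)NO)cc1`, 57.1%
compound 2, `Cc1ccc(-c2nc(CNc3ccc(C(=O)NO)cc3)n(-c3ccccc3)n2)cc1`, 62.2%
compound 3, `COc1ccc(-n2nc(-c3ccccc3)nc2CNc2ccc(C(=O)NO)cc2)cc1`, 63.4%

In an assay on Sf9 cells for inhibition of protein deacetylase HDAC6 (Homo sapiens), read by fluorescence, with a stated time of 40 min, tested at 100 nM (on this read-out lower numbers stand for less inhibition and higher numbers for more inhibition at the one concentration tested (going by the name of the read-out)), compound 3 gives 63.4%, the highest of the three numbers, though the gap to compound 2, at 62.2%, and the gap to compound 1, at 57.1%, both lie within the scatter, so the three compounds cannot be told apart on these data.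

Compound 4, `Cc1ccc(-n2nc(-c3ccccc3)nc2CNc2ccc(C(=O)NO)cc2)cc1`, has not yet been measured. It differs from compound 3 by methyl in place of methoxy on an aromatic carbon, on an aromatic carbon of a six-membered aromatic ring of carbon only, para to a large group.

For the measured compounds named here, only one measured step bears on this change, and only loosely: the change from 2-methylphenyl to 4-methoxyphenyl on the aromatic nitrogen, which gave a number 6.3 percentage points higher from compound 1 to compound 3 (within the scatter). Compound 2 carries a 4-methylphenyl elsewhere and shows a number close to compound 3. Nothing here points to a step beyond the scatter in this assay.

Compound 4 is therefore expected to give 60%, between 48% and 72%, an estimated step of a number 3.4 percentage points lower from compound 3 to compound 4 (within the scatter).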

Compound 4, a percentage reported as inhibition, at one concentration (the size of the read-out at that concentration, not a potency): 60.7%
Compound 4: middle estimate off by 0.7 percentage points, on the low side; measured number inside the range.
By their numbers in this assay, from the lowest: compounds 1, 4, 2 and 3 (each within the scatter of the next).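

In this assay, methyl in place of methoxy on an aromatic carbon, para to a large group, gives a number 2.7 percentage points lower from compound 3 to compound 4 (within the scatter), so this exchange, which removes the oxygen of the methoxy, does not separate the two compounds on this read-out. On the aromatic nitrogen, 4-methylphenyl in place of 2-methylphenyl gives a number 3.6 percentage points higher from compound 1 to compound 4 (within the scatter), so the methyl group's place on that aryl does not separate them either. Nothing available here offers an explanation for these small steps.

Compound 1, compound 3 and compound 4 carry only methyl or methoxy on this aryl, which leaves open whether an amine or a carboxylic acid there would give a step beyond the scatter. Going by these compounds, whether these compounds would differ at another concentration also remains open.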